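The source may report more compounds than this note shows. Statements on the series, on what has been measured and on what is new or still open speak of the compounds shown alone.

Working notes on the series, all in a functional assay on GBM3 cells (Homo sapiens) for antiproliferative activity, read by WST assay, with a stated time of 72 h; a higher number here means a weaker inhibitor, a lower number a stronger inhibitor. Among the measured compounds shown here, compound 3 `O=C(Nc1ccc(Cl)c(Cl)c1)Nc1cc2ncncc2cc1OCc1cccc(F)c1` gives 2000 nM, the lowest number of the three measured so far. Compound 1 `O=C(Nc1ccc(C(F)(F)F)cc1)Nc1cc2ncncc2cc1OCc1cccc(F)c1` gives 6300 nM, and compound 2 `O=C(Nc1cc2ncncc2cc1OCc1ccc(F)cc1)Nc1cccc2ccccc12` gives 8300 nM.

The next compound is compound 4 `O=C(Nc1cc2ncncc2cc1OCc1cccc(F)c1)Nc1cccc2ccccc12`, which differs from compound 3 in one place: naphthalen-1-yl in place of 3,4-dichlorophenyl on an amide-type nitrogen. Naphthalen-1-yl stands in place of 3,4-dichlorophenyl on an amide-type nitrogen.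

One measured step changes the group at this same place: a 3.2-fold lower number from compound 1 to compound 3 (0.50 log units; beyond the scatter). This modest step brings in 3,4-dichlorophenyl in place of 4-(trifluoromethyl)phenyl, so the group on this nitrogen can shift the number beyond the scatter. For the measured compounds named here, the only measured compound with naphthalen-1-yl is compound 2, at 8300 nM. Going by the values given here, it also differs from compound 4 elsewhere, and no measured step isolates that difference, so it serves only as a rough guide.

On the strength of compound 2 at 8300 nM, a move to a higher number is expected, of about the same size as the measured step. The estimated change is a 3.0-fold higher number from compound 3 to compound 4 (0.48 log units; beyond the scatter). Compound 4 is estimated at 6000 nM, with an expected range of 2500 nM to 13000 nM.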

Compound 4, half-maximal inhibitory concentration: 1200 nM
Compound 4: the middle estimate sits 5.0-fold (0.70 log units) above what was measured; the whole stated range lies above it.
By their numbers in this assay, from the lowest: compounds 4 and 3 (each within the scatter of the next); then compounds 1 and 2 (each within the scatter of the next).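

In this assay, naphthalen-1-yl and 3,4-dichlorophenyl on the amide-type nitrogen are not separated (a 1.7-fold lower number from compound 3 to compound 4 (0.22 log units; within the scatter)), so a group of only carbon with two aromatic rings reads the same here as a chlorinated single ring. Naphthalen-1-yl in place of 4-(trifluoromethyl)phenyl gives a change beyond the scatter (a 5.3-fold lower number from compound 1 to compound 4 (0.72 log units; beyond the scatter)), so with 3-fluorophenyl held fixed, two different groups now stand apart from 4-(trifluoromethyl)phenyl. Among the compounds shown here, the weak reading of compound 2 no longer speaks against naphthalen-1-yl: with that group held fixed, 3-fluorophenyl in place of 4-fluorophenyl on the saturated chain carbon bound to an oxygen on an aromatic ring gives the largest step so far (a 6.9-fold lower number from compound 2 to compound 4 (0.84 log units; beyond the scatter)), showing that the second place also moves the number. Nothing measured here accounts for these steps.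

Still open, from the compounds shown here alone, is how a cyclohexyl group or a phenyl carrying a morpholine would read on the amide-type nitrogen. Also open, going by these compounds, is whether 3,4-dichlorophenyl would lose as much as naphthalen-1-yl does when 4-fluorophenyl stands in place of 3-fluorophenyl.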